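A Bromine on the Five-Membered Ring of Compound 1

The source may report more compounds than this note shows. Statements on the series, on what has been measured and on what is new or still open speak of the compounds shown alone.

Compound 1 `CCCn1cnc2c(N)nc(NCc3ccccc3)nc21` carries a propyl group and a phenyl-bearing side chain on a shared core. In a functional assay on CHO cells for antagonist activity at adenosine receptor A2b (Homo sapiens) (a lower number here means a stronger inhibitor, a higher number a weaker inhibitor), compound 1 gives > 30000 nM, which is a limit of the assay rather than a measured number. Compound 2 `CCCn1cnc2c(N)nc(NCCCc3ccccc3)nc21`, with a longer side chain to the phenyl ring, also sits at a limit: in this assay compound 2 gives > 30000 nM. Both results stand at the limit of > 30000 nM in this assay, at which 2 of the 2 values shown sit, so compound 1 is no better resolved than the other value shown, and neither compound reaches a number that can be compared.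

Compound 3 `CCCn1c(Br)nc2c(N)nc(NCc3ccccc3)nc21` differs from compound 1 by bromo in place of hydrogen on an aromatic carbon. Going by the values given here, no measured pair shows what such a change does. Compound 3 is expected to stay weak, with only a small gain in inhibition at most. The expected step is an at least 1.5-fold lower number from compound 1 to compound 3 (0.17 log units; that floor lies within the scatter). Compound 3 is estimated at 20000 nM, with a likely range from 5000 nM to 30000 nM.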

Compound 3, inhibition constant: 1740 nM
For compound 3 the middle estimate is 11-fold (1.06 log units) above the measured one, and the stated range ends above it.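

Going by these compounds alone, a single bromo in place of hydrogen on an aromatic carbon of the five-membered ring gives the first readable number: in this assay the change brings an at least 17-fold lower number from compound 1 to compound 3 (1.23 log units; beyond the scatter). So this position, between two ring nitrogen atoms, responds to substitution, which the two earlier compounds could not show, since both stayed at a limit whatever the length of the side chain. The true size of the step stays unknown, because compound 1 holds only a limit and not a number: the limit of > 30000 nM in this assay, at which 2 of the 3 values shown sit.

The compounds shown leave open whether the gain belongs to bromine itself or would also come with another group here, such as chlorine, a methyl or an amine. They also leave open whether the longer side chain of compound 2 would give a readable number with the same bromo in place.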